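The source may report more compounds than this note shows. Statements on the series, on what has been measured and on what is new or still open speak of the compounds shown alone.

Of the compounds shown here, three built on one shared core have so far been tested in a functional assay (QGY7701 cells, Homo sapiens) for inhibition, read by MTT assay, with a stated time of 48 h; on this read-out higher numbers stand for weaker inhibition and lower numbers for stronger inhibition. Compound 1 `COc1ccc2c(=O)c(/C=C/C(=O)Nc3ccc(C)cc3)coc2c1` gives 39300 nM in this assay. Compound 3 `Cc1ccccc1NC(=O)/C=C/c1coc2cc(O)ccc2c1=O` gives 9320 nM in this assay. Compound 2 `COc1ccc2c(=O)c(/C=C/C(=O)Nc3ccc(Cl)cc3)coc2c1` sits at the assay limit > 100000 nM in this assay, a limit and not a number (the limit of > 100000 nM in this assay, at which 1 of the 3 values shown sits). Among the measured compounds shown here, the one measured step that bears on the change, an at least 2.5-fold higher number from compound 1 to compound 2 (0.40 log units; beyond the scatter), showed chloro in place of methyl weakening inhibition. Compound 4 `COc1ccc(NC(=O)/C=C/c2coc3cc(OC)ccc3c2=O)cc1` carries the change (methoxy in place of chloro on an aromatic carbon). The expected step of an at least 2.0-fold lower number from compound 2 to compound 4 (0.30 log units; that floor lies within the scatter) rests on the chloro being removed, with compound 1 at 39300 nM as the nearest anchor. Compound 4 is therefore estimated at 50000 nM, in a range from 15000 nM to 150000 nM.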

Compound 4, half-maximal inhibitory concentration: > 100000 nM
Compound 4: a limit, no number; the forecaster's own chance of this, stated with the estimate: 35%; middle value at least 2.0-fold (0.30 log units) away from the limit.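

In this assay compound 4 gives > 100000 nM, a limit and not a number. Methoxy in place of chloro therefore brings no readable value back, and the step between these two limits cannot be read: the limit of > 100000 nM in this assay, at which 2 of the 4 values shown sit. Methoxy in place of methyl gives an at least 2.5-fold higher number from compound 1 to compound 4 (0.40 log units; beyond the scatter), so both replacements of methyl shown here weaken inhibition at this position.

From the compounds shown here alone, whether an amine or a carboxylic acid here would give a value inside the range of this assay remains open. Compound 3 differs from the others in more than one place, so it cannot settle what this position contributes.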